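The compounds below may be only part of what the source reports. "The series", "measured", "known", "first", "only" and "open" are said of these compounds alone.

Measured in a functional assay on HeLa cells (Homo sapiens) for inhibition, read by MTT assay, with a stated time of 72 h; on this read-out lower numbers stand for stronger inhibition and higher numbers for weaker inhibition:
- compound 1 `COc1cc(NC(=O)/C=C/c2cccc(OCc3ccccc3)c2)cc(OC)c1OC`: 2200 nM
- compound 2 `C=C(Br)C(=O)Nc1cccc(/C=C/C(=O)Nc2ccc(OC)c(OC)c2)c1`: 560 nM
- compound 3 `C=C(Br)C(=O)Nc1cccc(/C=C/C(=O)Nc2cc(OC)cc(OC)c2)c1`: 2200 nM

Compound 3, at 2200 nM, stands level with compound 1, and together they hold the highest number of the three. Compound 2, at 560 nM, lies lower, beyond the scatter.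

The next compound is compound 4 `C=C(Br)C(=O)Nc1cccc(/C=C/C(=O)Nc2cc(OC)c(OC)c(OC)c2)c1`, which carries methoxy in place of hydrogen on an aromatic carbon, ortho to two methoxy groups and para to a large group: methoxy in place of hydrogen on an aromatic carbon. Within the data shown here, no measured pair isolates this kind of change, so the expectation rests on indirect evidence. Compound 4 keeps every methoxy group of compound 2, which gives 560 nM, so a moderate fall in this assay is expected, with the number moving toward that value. The expected change is a 2.8-fold lower number from compound 3 to compound 4 (0.44 log units; beyond the scatter), and a result within the scatter of the starting value would not be surprising. For compound 4 the estimated value is 800 nM, with an expected range of 250 nM to 2500 nM.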

Compound 4, half-maximal inhibitory concentration: 880 nM
Compound 4: the middle estimate sits 1.1-fold (0.04 log units) below what was measured; the range from low to high includes it.
By their numbers in this assay, from the lowest: compounds 2 and 4 (each within the scatter of the next); then compounds 1 and 3 (each within the scatter of the next).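

In this assay, methoxy in place of hydrogen on the aromatic carbon ortho to two methoxy groups and para to a large group gives a modest step, a 2.5-fold lower number from compound 3 to compound 4 (0.40 log units; beyond the scatter), while the same kind of change gives a 1.6-fold higher number from compound 2 to compound 4 (0.20 log units; within the scatter), so the methoxy pattern of compound 2 can take this further methoxy without a change beyond the scatter. Among these compounds, with the three methoxy groups of compound 1 kept, ((1-bromoethenyl)carbonyl)amino in place of benzyloxy gives a modest step too, a 2.5-fold lower number from compound 1 to compound 4 (0.40 log units; beyond the scatter), the first reading of that exchange. No measurement shown gives a reason for either step.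

The compounds shown leave open whether methoxy itself matters at this carbon, which a hydroxyl group, a fluorine atom or an ethoxy group there would help settle. Also open, on these data alone, is the part played by the bromine, which a plain acetylamino group in place of the ((1-bromoethenyl)carbonyl)amino group would test.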